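This account rests on a few compounds, and the source may have more. Where it says the series, first, only, none or still open, it means among the compounds named here.

Compound 1 `CCCCCCCCc1ccc(OCC(=O)Cn2nnc(C)n2)cc1`: in an ADME assay on S9 fraction from liver (Rattus norvegicus) for metabolic stability, read by LC-MS, using NADPH, with a stated time of 30 min (on this read-out higher numbers stand for a more stable compound and lower numbers for a less stable compound), compound 1 gives < 5%, which is a limit of the assay rather than a number.
Compound 2 `CCCCCCCCc1ccc(OCC(=O)Cn2nnc(-c3ccc(Cl)cc3)n2)cc1`: compound 2 gives 74%.
Compound 3 `CCCCCCCCc1ccc(OCC(=O)Cn2nnc(-c3cccc(Cl)c3)n2)cc1`: compound 3 gives 69%.

Compound 1 thus stands at the limit of < 5% in this assay, at which 1 of the 3 values shown sits; of the three values shown, only its own sits there, so its true position on the scale is not known beyond that limit. The unmeasured compound 4 `CCCCCCCCc1ccc(OCC(=O)Cn2nnc(-c3cccs3)n2)cc1` differs from compound 1 in one place: thiophen-2-yl in place of methyl on an aromatic carbon.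

Within the data shown here, two measured steps bear on this change, since both replace the same methyl by an aromatic ring at the same position. The step of a number at least 69 percentage points higher from compound 1 to compound 2 (beyond the scatter) and the step of a number at least 64 percentage points higher from compound 1 to compound 3 (beyond the scatter) were both large. Between the two ring-bearing compounds the step of a number 5 percentage points lower from compound 2 to compound 3 (within the scatter) lies within the scatter, so the two chlorophenyl compounds show no order between them. A thiophen-2-yl ring is a smaller aromatic group than either chlorophenyl ring, but on these data a large rise beyond the scatter in this assay is the expectation for compound 4 as well.

Compound 4 is therefore estimated at 55%, with a range from 25% to 80%. This corresponds to an expected step of a number at least 50 percentage points higher from compound 1 to compound 4 (beyond the scatter).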

Compound 4, percent of the compound remaining: 8%
Estimate against measurement, compound 4: 47 percentage points above; the whole stated range lies above it.
By their numbers in this assay, from the lowest: compound 4; then compounds 3 and 2 (each within the scatter of the next). At a limit, below all of these: compound 1.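

In this assay, an aromatic ring on this carbon does not by itself bring the large rise, for the step with thiophen-2-yl reads a number at least 3 percentage points higher from compound 1 to compound 4 (that floor lies within the scatter). Compound 1 stands at a limit and not at a number, so that step has only a floor: the limit of < 5% in this assay, at which 1 of the 4 values shown sits. Set against the two chlorophenyl compounds, the same ring gives a number 61 percentage points lower from compound 3 to compound 4 (beyond the scatter) and a number 66 percentage points lower from compound 2 to compound 4 (beyond the scatter), which shows that among the compounds shown the high values belong to the two chlorophenyl rings and not to aromatic rings at this position in general.

The compounds shown do not separate the part played by the chlorine from that played by the ring carrying it, a question that a plain phenyl group or a thiophen-3-yl group on the same carbon would bear on. They also give no reason for the gap between thiophen-2-yl and the chlorophenyl rings, and they leave open whether these differences would persist with a shorter chain in place of the long chain on the shared core.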